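Inverting the Chain Stereocentre of Compound 1

The source may report more compounds than this note shows. Statements on the series, on what has been measured and on what is new or still open speak of the compounds shown alone.

Compound 1 `O[C@H](COc1ccc(C(F)(F)F)cc1)CN1CCN(c2ccccc2F)CC1` — 48.9%
Compound 2 `O[C@H](COc1ccc(C(F)(F)F)cc1)CN1CCN(c2ccc(F)cc2)CC1` — 59.2%
Compound 3 `O[C@H](COc1ccc(Cl)cc1)CN1CCN(c2ccccc2F)CC1` — 35.9%

In an assay on HEK293 cells for inhibition of Voltage-dependent T-type calcium channel subunit alpha-1G (Homo sapiens), read by patch clamp, tested at 10 uM (a higher number here means more inhibition at the concentration tested (going by the name of the read-out), a lower number less inhibition), compound 1 gives 48.9%, the second highest of the three numbers. The two measured steps are a number 10.3 percentage points higher from compound 1 to compound 2 (beyond the scatter) and a number 13 percentage points lower from compound 1 to compound 3 (beyond the scatter); both are modest, and both change a substituent on an aromatic ring. Compound 4 `O[C@@H](COc1ccc(C(F)(F)F)cc1)CN1CCN(c2ccccc2F)CC1` has not been measured. the two compounds have the same atoms and bonds and differ only in configuration as drawn: 1 of 1 stereo elements differ; a stereocentre at a saturated chain carbon is drawn S in compound 1 and R in compound 4 Neither measured step touches that stereocentre, so the measured compounds give no direct guide to an inversion of configuration. In the absence of such a guide, the step of a number 3.9 percentage points lower from compound 1 to compound 4 (within the scatter) is expected to lie within the scatter, but with a wide range on either side. Compound 4 is therefore estimated at 45%, between 25% and 65%.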

Compound 4, a percentage reported as inhibition, at one concentration (the size of the read-out at that concentration, not a potency): 50.2%
Beside the measured number, compound 4's estimate is 5.2 percentage points below it, and the stated range covers the measured number.
By their numbers in this assay, from the lowest: compound 3; then compounds 1, 4 and 2 (each within the scatter of the next, the first and the last beyond it).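

In this assay, inverting the chain stereocentre gives a number 1.3 percentage points higher from compound 1 to compound 4 (within the scatter), whereas the two aromatic substituent steps, a number 10.3 percentage points higher from compound 1 to compound 2 (beyond the scatter) and a number 13 percentage points lower from compound 1 to compound 3 (beyond the scatter), lie beyond the scatter. For the compounds shown here, this is the first reading at this carbon, and with the rest of the structure held constant, the drawn configuration makes no readable difference at the concentration tested. The comparison isolates this one feature: the fact that compounds 1 and 4 differ only in the configuration as drawn

From the compounds shown here alone, whether this also holds with 4-fluorophenyl or chloro in the molecule remains open. So does the outcome of replacing the hydroxyl at this carbon with an amine or a methoxy group.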